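The source may hold more compounds than are shown below. What is called first, only, known or untested is meant among the compounds shown, and "the series" means these compounds.

Compound 1 `COC(=O)C1=C(C)N=C(C)/C(=C(\O)OC)C1c1ccccc1Cl` carries a chloro group on its phenyl ring and, in a functional assay (muscle tissue) with Cavia porcellus as the target (on this read-out higher numbers stand for an effect only at larger amounts of compound and lower numbers for an effect already at smaller amounts), compound 1 gives 2.19 nM, the lowest of the three numbers seen so far. Compound 2 `COC(=O)C1=C(C)N=C(C)/C(=C(\O)OC)C1c1cccc([N+](C)(C)C)c1` gives 50100 nM in this assay, and compound 3 `COC(=O)C1=C(C)N=C(C)/C(=C(\O)OC)C1c1cccc(OC(=O)c2ccccc2)c1` gives 6310 nM. Against these two, compound 1 stands far apart: its number is lower than that of compound 3 by a wide margin and lower still against compound 2, both gaps well beyond the scatter.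

Compound 4 `COC(=O)C1=C(C)N=C(C)/C(=C(\O)OC)C1c1ccccc1I` differs from compound 1 in one place: iodo in place of chloro on an aromatic carbon. Going by the values given here, the only measured step, a 7.9-fold lower number from compound 2 to compound 3 (0.90 log units; beyond the scatter), concerns a different part of the ring and exchanges groups of very different size and charge, so it says little about swapping one halogen for another on the same carbon. Among the compounds with values here, no measured pair shows what a halogen exchange does here, and both halogens carry no donors, acceptors or charge.

The expectation is therefore that compound 4 stays close to compound 1, with a step of a 1.1-fold higher number from compound 1 to compound 4 (0.06 log units; within the scatter), not clearly beyond the scatter. Compound 4 is expected to give about 2.5 nM in this assay, within a range from 0.7 nM to 9 nM.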

Compound 4, half-maximal effective concentration: 46.8 nM
The estimate for compound 4 lay 19-fold (1.27 log units) below the measured number; the measured number lies above the stated range.
By their numbers in this assay, from the lowest: compound 1; then compound 4; then compound 3; then compound 2.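

In this assay, the exchange of chloro for iodo is far from a neutral swap: it gives a 21-fold higher number from compound 1 to compound 4 (1.33 log units; beyond the scatter) and so shows that this aromatic carbon responds strongly to which halogen it carries. The counts computed from the two structures do not separate the two groups, since each is a single heavy atom with no ring, no hydrogen-bond donors or acceptors and no net charge, so those counts alone would not have flagged this change. No measurement of any property of these two groups is at hand to explain the step.

On these data alone, two halogens cannot show whether the number climbs steadily from one halogen to the next, so what a fluoro or a bromo group would give on the same carbon remains open. Also open, as far as these compounds go, is what a group that is not a halogen, such as a methyl group or an amine, would give there, and whether iodo on a different carbon of the phenyl ring would move the number as much.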